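Isoxazole for imidazole on the sulfonyl of compound 3

The compounds below may be only part of what the source reports. "The series", "measured", "known", "first", "only" and "open" are said of these compounds alone.

The series shares a core shown by compound 1 `CCN(Cc1ccccc1)C(=O)C1CCN(S(=O)(=O)c2cccc(OC)c2)CC1`, which in a functional assay on CHO cells for positive allosteric modulation of muscarinic acetylcholine receptor M5 (Homo sapiens), read by calcium flux (a higher number here means that more compound is needed for the effect, a lower number that less compound is needed), gives 3090 nM; 3100 nM (2 entries). Compound 2 `CCN(Cc1ccccc1)C(=O)C1CCN(S(=O)(=O)c2ccc(OC)c(OC)c2)CC1` reaches only a limit of the assay in this assay, > 10000 nM; > 10000 nM (2 entries). Compound 3 `CCN(Cc1ccccc1)C(=O)C1CCN(S(=O)(=O)c2c[nH]cn2)CC1` likewise stands only at a limit in this assay, > 10000 nM, so no single number is known for it. Compound 4 `CCN(Cc1ccccc1)C(=O)C1CCN(S(=O)(=O)c2c(C)noc2C)CC1` carries 3,5-dimethyl-1,2-oxazol-4-yl in place of 1H-imidazol-4-yl on a sulfonyl sulfur. Going by the values given here, no measured step of the same kind exists in this assay, so the expected size of the step is open; a small move in either direction, or none beyond the scatter, is plausible. Compound 4 is estimated at 7000 nM, within 2000 nM to 20000 nM, with the expected step of an at least 1.4-fold lower number from compound 3 to compound 4 (0.15 log units; that floor lies within the scatter).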

Compound 4, half-maximal effective concentration: > 10000 nM
Compound 4: no number, only a limit; the forecaster's own chance of this, stated with the estimate: 55%; at least 1.4-fold (0.15 log units) between middle value and limit.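

Going by these compounds alone, compound 3 and compound 4 both stand only at a limit in this assay, so no step between them can be read. The compounds shown leave open whether 3,5-dimethyl-1,2-oxazol-4-yl and 1H-imidazol-4-yl differ at all on the sulfonyl sulfur.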